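The compounds below may be only part of what the source reports. "The series", "measured", "known", "first", "only" and "open" are said of these compounds alone.

Measured in an ADME assay on microsomes from liver (Rattus norvegicus) for metabolic stability (on this read-out lower numbers stand for slow clearance and higher numbers for fast clearance), so far:
- Compound 1 `O=C(O)CCNC(=O)c1ccc(C(Oc2ccc(-n3cc(C(F)(F)F)cn3)cc2)C2CC2)cc1` gives < 25 mL/min/kg (a limit)
- Compound 2 `O=C(O)CCNC(=O)c1ccc(C(Oc2ccc(-n3cc(C(F)(F)F)cn3)cc2)C2CCC2)cc1` gives < 25 mL/min/kg (a limit)

Compound 2 has no exact number in this assay and stands only at the limit of < 25 mL/min/kg and not at a measured clearance. Going by the values given here, the one other value shown is also a limit, so the limit of < 25 mL/min/kg in this assay, at which 2 of the 2 values shown sit, describes everything known so far.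

Compound 3 `CCCC(Oc1ccc(-n2cc(C(F)(F)F)cn2)cc1)c1ccc(C(=O)NCCC(=O)O)cc1` has not yet been measured. Its change from compound 2 is propyl in place of cyclobutyl on a saturated chain carbon bound to an aromatic carbon and an oxygen on an aromatic ring, with propyl in place of cyclobutyl on a saturated chain carbon bound to an aromatic carbon and an oxygen on an aromatic ring.

Among the compounds with values here, the only measured step at this place is a step that the two limits leave unreadable from compound 1 to compound 2, with cyclobutyl in place of cyclopropyl. It gives no size to carry over and no direction. No step beyond the usual scatter is therefore expected, though this expectation is weakly founded, and another limit would fit it. The expected change is a step that the limit leaves unreadable from compound 2 to compound 3 and it remains uncertain. For compound 3 the estimated clearance is 20 mL/min/kg, with an expected range from 10 mL/min/kg to 40 mL/min/kg.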

Compound 3, clearance: < 36 mL/min/kg
Compound 3 ended at the assay's limit; the forecaster's own chance of this, stated with the estimate: 70%; the middle value lies beyond the limit too.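

In this assay compound 3 gives < 36 mL/min/kg, which is a limit and not a number. Going by these compounds alone, compound 1 and compound 2 also stand only at limits, so no step among compound 1, compound 2 and compound 3 can be read. The compounds shown leave open whether cyclopropyl, cyclobutyl and propyl at this place differ in clearance at all.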